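Dichloro and monochloro purine analogues with chloromethylbenzyl substituents

The source may hold more compounds than are shown below. What is called first, only, known or untested is meant among the compounds shown, and "the series" means these compounds.

Compound 1 `ClCc1ccccc1Cn1cnc2nc(Cl)nc(Cl)c21` has no number of its own in a functional assay on HCT-116 cells (Homo sapiens) for cytotoxicity, read by sulforhodamine B assay, with a stated time of 48 h; a lower number here means that less compound is tolerated, a higher number that more compound is tolerated; its entry there is "not determined" (no result reported), so the series gives no measured starting point for it. Going by the values given here, the only measured neighbour is compound 2 `ClCc1ccc(Cn2cnc3c(Cl)nc(Cl)nc32)cc1`, which in this assay gives 7590 nM. Among the compounds with values here, no step between measured compounds is available, so nothing can be said about how the change itself acts on the read-out. Compound 3 `ClCc1ccccc1Cn1cnc2ncnc(Cl)c21` differs from compound 1 by hydrogen in place of chloro on an aromatic carbon. The expected step from compound 1 to compound 3 in this assay cannot be sized from these data, and neither direction nor a change beyond the scatter can be ruled in or out. With compound 2 at 7590 nM as the only anchor, compound 3 is expected to give about 12000 nM in this assay, within a range from 2500 nM to 60000 nM.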

Compound 3, concentration lethal to 50% of the cells: 40700 nM
For compound 3 the middle estimate is 3.4-fold (0.53 log units) below the measured one, and the stated range covers the measured number.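

With no single number for compound 1 in this assay, the step from compound 1 to compound 3 cannot be read. The compounds shown leave open how exchanging chloro for hydrogen acts on the read-out. No evidence is available that bears on this result.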